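The compounds below may be only part of what the source reports. "The series", "measured", "known", "first", "only" and "open" are said of these compounds alone.

Working notes on the series. For the measured compounds named here, compound 2 `Cc1ccc2nc(C(=O)Nc3c(F)cc(-c4cccc(F)c4)cc3F)c(C)c(C(=O)O)c2c1` holds the smaller of the two numbers so far in a functional assay on A-375 cells (Homo sapiens) for antiproliferative activity, read by MTT assay, with a stated time of 24 h, tested at 11.11 ug/mL (on this read-out higher numbers stand for a stronger effect at the one concentration tested and lower numbers for a weaker effect), where compound 2 gives 19.2%. Going by the values given here, the only other measured member, compound 1 `CCc1ccc2nc(C(=O)Nc3c(F)cc(-c4cccc(F)c4)cc3F)c(C)c(O)c2c1`, gives 26.4% in this assay; the gap between the two values lies within the scatter, so the two read alike. Among the compounds with values here, compound 1 and compound 2 differ in more than one place, and no single-point step between measured compounds is available.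

Compound 3 `CCc1ccc2nc(C(=O)Nc3c(F)cc(-c4cccc(F)c4)cc3F)c(C)c(C(=O)O)c2c1` has not been measured. It differs from compound 2 by methyl in place of hydrogen on a saturated chain carbon bound to an aromatic carbon. Within the data shown here, no measured step bears on this change, so the expectation rests on the two values in hand: the expected step is a number 2.8 percentage points higher from compound 2 to compound 3 (within the scatter), none beyond the scatter in either direction. Compound 3 is therefore estimated at 22%, with a range from 10% to 35%.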

Compound 3, a percentage reported as inhibition, at one concentration (the size of the read-out at that concentration, not a potency): 38.9%
Estimate against measurement, compound 3: 16.9 percentage points below; measured number above the stated range.
By their numbers in this assay, from the lowest: compounds 2 and 1 (each within the scatter of the next); then compound 3.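

In this assay, for the compounds shown here, methyl in place of hydrogen on a saturated chain carbon bound to an aromatic carbon gives a number 19.7 percentage points higher from compound 2 to compound 3 (beyond the scatter) and so provides the first single-place evidence that this position affects the read-out. Carboxy in place of hydroxy on an aromatic carbon, with ethyl held constant, gives a number 12.5 percentage points higher from compound 1 to compound 3 (beyond the scatter) and shows that this second place also matters in the ethyl series. No measurement shown here accounts for either step.

The compounds shown leave open whether a propyl chain at the first place would extend the step seen on going from methyl to ethyl, and whether a cyclopropyl group would do the same. They also leave open how a primary amide or a methyl ester would compare with the carboxy group at the second place.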